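This account rests on a few compounds, and the source may have more. Where it says the series, first, only, none or still open, it means among the compounds named here.

Compound 1 `Nc1sc2cnccc2c1C(=O)c1ccccc1` gives 0% in an assay on CHO cells for displacement of a labelled ligand from adenosine receptor A3 (Homo sapiens), tested at 10 uM; a higher number here means more inhibition at the concentration tested (going by the name of the read-out), a lower number less inhibition. Compound 2 `Nc1sc2cnccc2c1C(=O)c1ccc(Cl)cc1`, which carries chloro in place of hydrogen on an aromatic carbon, gives 0% in this assay; the step of no change at the digits printed from compound 1 to compound 2 (within the scatter) leaves compound 2 level with compound 1 at the digits shown, within the scatter. Compound 3 `Nc1sc2cnccc2c1C(=O)c1ccc(Cl)c(Cl)c1` is the next member of this series, differing from compound 2 by chloro in place of hydrogen on an aromatic carbon. For the measured compounds named here, the only measured step that bears on this change is no change at the digits printed from compound 1 to compound 2 (within the scatter), which brought nothing beyond the scatter. A second chloro entering in the same way is therefore expected to leave the read-out essentially where it stands, and the expected step is no change at the digits printed from compound 2 to compound 3 (within the scatter). For compound 3 the estimate in this assay is 0%, with a range from -10% to 15%.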

Compound 3, a percentage reported as inhibition, at one concentration (the size of the read-out at that concentration, not a potency): 0%
The estimate for compound 3 equals the measured number at the digits printed; the range from low to high includes it.
By their numbers in this assay, from the lowest: compounds 1, 2 and 3 (each within the scatter of the next).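

Chloro in place of hydrogen at this new place, on an aromatic carbon ortho to a chloro group and meta to a large group, brings no change at the digits printed from compound 2 to compound 3 (within the scatter) in this assay at the single concentration tested. The earlier compounds shown here showed this change at only one place, with no change at the digits printed from compound 1 to compound 2 (within the scatter) as the step, so the same replacement has now been seen at two places on the six-membered aromatic ring of carbon only. Across these two steps, adding chloro gives no reading that stands apart from the earlier one, and neither step goes against this.

From the compounds shown here alone, whether an amine, a hydroxyl group or a carboxylic acid at this place would give a different reading from compound 2 remains open. Nothing measured here explains why the second chloro leaves the reading unchanged.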